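Shortening the Tether of Compound 1 by One Carbon

A few compounds are considered here, and "the series" means these few. Any claim that something is new, unique, unknown or untested is made for them only; others in the source may bear on it.

Compound 1 `O=C(CI)NCCCC(=O)NCCCCCCNc1ncnc2c1ncn2[C@@H]1O[C@H](COP(=O)(O)OP(=O)(O)OP(=O)(O)O)[C@@H](O)[C@H]1O` was examined in an assay on isolated protein for inhibition of hexokinase-1 (Rattus norvegicus), with a stated time of 6 h, tested at 10 mM (a higher number here means more inhibition at the concentration tested (going by the name of the read-out), a lower number less inhibition), and gave 0%. A second compound built on the same core but carrying a different tether, compound 2 `CN(CCCN(C)C(=O)CCCNc1ncnc2c1ncn2[C@@H]1O[C@H](COP(=O)(O)OP(=O)(O)OP(=O)(O)O)[C@@H](O)[C@H]1O)C(=O)CCCNC(=O)CI`, gave in this assay a reading of 0%. Compound 1 therefore stands level with compound 2 at the digits shown; the two values lie within the scatter of each other, and neither compound shows inhibition at the concentration tested.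

Compound 3 `O=C(CI)NCCC(=O)NCCCCCCNc1ncnc2c1ncn2[C@@H]1O[C@H](COP(=O)(O)OP(=O)(O)OP(=O)(O)O)[C@@H](O)[C@H]1O` has not been measured. It differs from compound 1 in a single place: ((iodomethyl)carbonyl)amino in place of (((iodomethyl)carbonyl)amino)methyl on a saturated chain carbon, two bonds along the chain from a carbonyl carbon. Everything else, including the shared core of compound 1, is kept.

Among the compounds with values here, with no step between measured compounds to draw on, the expectation rests on the two values alone. Because compound 1 gives 0% and compound 2 gives 0%, removing one chain carbon from the tether is expected to produce no step beyond the scatter, a change estimated at no change at the digits printed from compound 1 to compound 3 (within the scatter). Compound 3 is accordingly expected to give 0%, within a range from -5% to 10%.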

Compound 3, a percentage reported as inhibition, at one concentration (the size of the read-out at that concentration, not a potency): 0%
Compound 3: the middle estimate sits on the measured number at the digits printed; low and high end bracket the measured number.
By their numbers in this assay, from the lowest: compounds 1, 2 and 3 (each within the scatter of the next).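

Within the data shown here, putting ((iodomethyl)carbonyl)amino in place of (((iodomethyl)carbonyl)amino)methyl on a saturated chain carbon, two bonds along the chain from a carbonyl carbon, gives no change at the digits printed from compound 1 to compound 3 (within the scatter) in this assay and is the first change in this small set that can be read at a single place. Shortening the tether at this position therefore does not bring out inhibition, and compound 3 reads 0% in this assay at the one concentration tested, so the step gives no sign of any dependence on tether length across this change. With no inhibition to compare, the step cannot rank the two tethers, and nothing at hand offers an account of the result.

The compounds shown leave open whether any tether at this position can produce a reading in this assay that differs from these, for instance a longer chain carrying the same ((iodomethyl)carbonyl)amino end. On these data alone, it is equally open whether an amine or a carboxylic acid in place of that end would change the reading.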